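A few compounds are considered here, and "the series" means these few. Any claim that something is new, unique, unknown or untested is made for them only; others in the source may bear on it.

Compound 1 `COc1cc(/C=C/C(=O)c2cc(-c3cc(OC)c(OC)c(OC)c3)n3nc(-c4ccccc4)cc3n2)cc(OC)c1OC` gives 17900 nM in a functional assay on DU-145 cells (Homo sapiens) for antiproliferative activity, read by MTT assay, with a stated time of 24 h; a lower number here means a stronger inhibitor, a higher number a weaker inhibitor.
Compound 2 `COc1cc(-c2cc(/C=C/C(=O)c3ccc(C)cc3)nc3cc(-c4ccccc4)nn23)cc(OC)c1OC` gives 27100 nM in this assay.
Compound 3 `COc1ccc(C(=O)/C=C/c2cc(-c3cc(OC)c(OC)c(OC)c3)n3nc(-c4ccccc4)cc3n2)cc1` gives 25200 nM in this assay.

All three measured compounds share the same core, carrying a trimethoxyphenyl group, a phenyl group and an enone side chain, and all three give weak numbers. In this assay compound 3 stands second highest of the three numbers. Its nearest neighbour is compound 2: the measured step of a 1.1-fold lower number from compound 2 to compound 3 (0.03 log units; within the scatter) is within the scatter. Its furthest neighbour is compound 1, and the two values of compound 1 and compound 3 also lie within the scatter of each other, so no order among the three can be claimed.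

Compound 4 `COc1cc(-c2cc(C(=O)/C=C/c3ccccc3)nc3cc(-c4ccccc4)nn23)cc(OC)c1OC` is the next compound in the series. It differs from compound 3 in one place: (2-phenylethenyl)carbonyl in place of 2-((4-methoxyphenyl)carbonyl)ethenyl on an aromatic carbon. Among the compounds with values here, only one measured step bears on this change, a 1.1-fold lower number from compound 2 to compound 3 (0.03 log units; within the scatter), which touched the same side chain and produced no movement beyond the scatter. The step into compound 4 is larger, reversing which end of the enone carries the carbonyl and dropping the methoxy, but compound 1, which also carries the carbonyl on the core, sits within the scatter of compound 3. The step of a 1.1-fold lower number from compound 3 to compound 4 (0.06 log units; within the scatter) is therefore expected to stay within the scatter. Compound 4 is estimated at 22000 nM, with a range from 8000 nM to 60000 nM.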

Compound 4, half-maximal inhibitory concentration: 16300 nM
Estimate against measurement, compound 4: 1.3-fold (0.13 log units) above, and the stated range covers the measured number.
By their numbers in this assay, from the lowest: compounds 4, 1, 3 and 2 (each within the scatter of the next).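

At this position on the shared core, next to the ring nitrogen, the enone chain can be attached either way round without a shift beyond the scatter: replacing 2-((4-methoxyphenyl)carbonyl)ethenyl with (2-phenylethenyl)carbonyl gives a 1.5-fold lower number from compound 3 to compound 4 (0.19 log units; within the scatter), and replacing 2-((4-methylphenyl)carbonyl)ethenyl with the same group gives a 1.7-fold lower number from compound 2 to compound 4 (0.22 log units; within the scatter). The far end of the chain proves just as tolerant in this assay, since phenyl in place of 3,4,5-trimethoxyphenyl gives a 1.1-fold lower number from compound 1 to compound 4 (0.04 log units; within the scatter), so a chain ring with no methoxy groups at all reads the same as one with three. No measurement at hand explains why these changes leave the number within the scatter.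

From the compounds shown here alone, every change so far keeps an enone chain ending in an aromatic ring, so it remains open whether a chain ending in an amine or a carboxylic acid would move the number beyond the scatter. Also open, going by these compounds, is whether a change elsewhere on the core, such as a pyridine ring in place of the phenyl group or of the 3,4,5-trimethoxyphenyl group, would do so.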